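Swapping the Aryl Group on the Sulfonyl Sulfur

The source may report more compounds than this note shows. Statements on the series, on what has been measured and on what is new or still open speak of the compounds shown alone.

Compound 3 `CC1CCN(C2CCN(S(=O)(=O)c3ccc(C#N)cc3)CC2)CC1` has the highest number of the three measured compounds in a functional assay on DLD-1 cells (Homo sapiens) for antiproliferative activity, read by CellTiter-Glo, with a stated time of 72 h (on this read-out higher numbers stand for weaker inhibition and lower numbers for stronger inhibition), where compound 3 gives 2800 nM. Its nearest neighbour is compound 2 `CC1CCN(C2CCN(S(=O)(=O)c3cnc(Cl)s3)CC2)CC1`, which in this assay gives 1800 nM; the two lie within the scatter of each other. Compound 1 `Cc1nc(Cl)sc1S(=O)(=O)N1CCC(N2CCC(C)CC2)CC1` stands far apart, since in this assay compound 1 gives 1.6 nM.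

Compound 4 `CC1CCN(C2CCN(S(=O)(=O)c3cncc(Br)c3)CC2)CC1` differs from compound 3 in one place: 5-bromopyridin-3-yl in place of 4-cyanophenyl on a sulfonyl sulfur. The most direct precedent is the aryl swap on the sulfonyl sulfur a 1.6-fold higher number from compound 2 to compound 3 (0.19 log units; within the scatter), which stayed within the scatter. The large steps of a 1100-fold higher number from compound 1 to compound 2 (3.05 log units; beyond the scatter) and a 1800-fold higher number from compound 1 to compound 3 (3.24 log units; beyond the scatter) both turn on the loss of the methyl on an aromatic carbon of compound 1, a feature that neither compound 3 nor compound 4 carries, so they offer no guide to this change. The expectation for compound 4 is therefore a step of about a 1.1-fold lower number from compound 3 to compound 4 (0.05 log units; within the scatter), not beyond the scatter. Compound 4 is estimated at 2500 nM, with a range from 800 nM to 8000 nM.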

Compound 4, half-maximal inhibitory concentration: > 5000 nM
Compound 4 ended at the assay's limit; the forecaster's own chance of this, stated with the estimate: 10%; middle value at least 2.0-fold (0.30 log units) away from the limit.
By their numbers in this assay, from the lowest: compound 1; then compounds 2 and 3 (each within the scatter of the next). At a limit, above all of these: compound 4.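

In this assay compound 4 ends at a limit of the assay and not at a number: the limit of > 5000 nM in this assay, at which 1 of the 4 values shown sits. Among the compounds without the methyl of compound 1, this position now shows a change beyond the scatter, with an at least 2.7-fold higher number from compound 2 to compound 4 (0.44 log units; beyond the scatter), so 5-bromopyridin-3-yl gives weaker inhibition here than 2-chloro-1,3-thiazol-5-yl, while the floor of an at least 1.7-fold higher number from compound 3 to compound 4 (0.25 log units; that floor lies within the scatter) does not settle any order for that pair. Set against compound 1, the step is an at least 3100-fold higher number from compound 1 to compound 4 (3.49 log units; beyond the scatter), which extends the large gap already seen for the two earlier compounds.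

The compounds shown leave open how far past the limit compound 4 lies, and whether the methyl of compound 1 would have the same effect on any other aryl group. They also leave open what an amine or a methoxy group on the aryl ring would do in this assay.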